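Swapping Methoxy for Bromo on the Aryl Ring

A few compounds are considered here, and "the series" means these few. Any claim that something is new, unique, unknown or untested is made for them only; others in the source may bear on it.

Compound 1 `COc1ccc(-c2cnc3scc(C(=O)NNC(C)=O)n23)cc1` and compound 2 `CCCC(=O)NNC(=O)c1csc2ncc(-c3ccc(OC)cc3)n12` share one core and differ at a saturated chain carbon bound to a carbonyl carbon, where compound 2 carries an ethyl in place of hydrogen. In a functional assay on PC-3 cells (Homo sapiens) for antiproliferative activity, read by MTT assay, with a stated time of 72 h (a higher number here means a weaker inhibitor, a lower number a stronger inhibitor), compound 1 gives 28300 nM, and compound 2 gives 66400 nM. Among the compounds with values here, that change produced a 2.3-fold higher number from compound 1 to compound 2 (0.37 log units; beyond the scatter), so compound 2 stands with the highest number of the two measured here, its only neighbour being compound 1.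

Compound 3 `CCCC(=O)NNC(=O)c1csc2ncc(-c3ccc(Br)cc3)n12` keeps the chain of compound 2 and alters the aromatic ring instead: bromo in place of methoxy on an aromatic carbon. Within the data shown here, no measured step involves this same exchange; the single measured step, a 2.3-fold higher number from compound 1 to compound 2 (0.37 log units; beyond the scatter), concerns a different part of the molecule and therefore gives no direct guide. Without a measured precedent, the expected step of a 1.1-fold lower number from compound 2 to compound 3 (0.04 log units; within the scatter) in this assay is none beyond the scatter, though the uncertainty in either direction is wide. Compound 3 is therefore estimated at 60000 nM, with a range from 20000 nM to 180000 nM.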

Compound 3, half-maximal inhibitory concentration: 58500 nM
Estimate against measurement, compound 3: 1.0-fold (0.01 log units) above; low and high end bracket the measured number.
By their numbers in this assay, from the lowest: compound 1; then compounds 3 and 2 (each within the scatter of the next).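

Within the data shown here, until now, the only change seen was at the chain end, so this is the first reading at the aromatic ring, on a carbon para to a large group. In this assay, going from 4-methoxyphenyl to 4-bromophenyl gives a 1.1-fold lower number from compound 2 to compound 3 (0.06 log units; within the scatter) and so leaves the result within the scatter of repeated measurements. Methoxy brings two heavy atoms and a hydrogen-bond acceptor while bromo brings one heavy atom and no acceptor, yet this assay does not separate compound 2 from compound 3, and no supporting data offer an explanation for this likeness.

This exchange has been read only with the butanoyl-type chain of compound 2 and compound 3, so the same swap on the shorter chain of compound 1 remains an open question. Also open, as far as these compounds go, is whether a group of a different kind on that same aromatic carbon, such as an amine or a carboxylic acid, would move the number beyond the scatter, or whether this position tolerates such groups as evenly as it does methoxy and bromo.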